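Methyl for Fluoro on an Alcohol and a Ketone Core

A few compounds are considered here, and "the series" means these few. Any claim that something is new, unique, unknown or untested is made for them only; others in the source may bear on it.

Compound 1, with structure `OCCCCCC(O)c1ccc(-c2ccc(F)cc2F)cc1`, and compound 2, with structure `Cc1cc(F)ccc1-c1ccc(C(O)CCCCCO)cc1`, share a core built around an alcohol and differ in one place: methyl in place of fluoro on an aromatic carbon. In a functional assay on J774 cells (Mus musculus) for cytotoxicity, read by resazurin assay (a lower number here means a stronger inhibitor, a higher number a weaker inhibitor), compound 1 gives 8000 nM, while compound 2 gives 20000 nM; the step between them is a 2.5-fold higher number from compound 1 to compound 2 (0.40 log units; beyond the scatter).

Compound 3, with structure `O=C(CCCCCO)c1ccc(-c2ccc(F)cc2F)cc1`, carries a carbonyl where compound 1 carries an alcohol; the difference between the two cores is not broken down here. In this assay, for the measured compounds named here, compound 3 gives 6000 nM, the lowest of the three numbers so far, although its gap to compound 1 lies within the usual scatter.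

Compound 4, with structure `Cc1cc(F)ccc1-c1ccc(C(=O)CCCCCO)cc1`, has not yet been measured. It differs from compound 3 in one place: methyl in place of fluoro on an aromatic carbon. The place of this change is described in exactly the same words as for the pair of compound 1 and compound 2, so it is the same change seen a second time, now on the ketone core rather than the alcohol core.

The expectation for compound 4 rests on that single earlier instance. In this assay the step of a 2.5-fold higher number from compound 3 to compound 4 (0.40 log units; beyond the scatter) is expected, because the matched step a 2.5-fold higher number from compound 1 to compound 2 (0.40 log units; beyond the scatter) went in that direction and by that size. Compound 4 is therefore estimated at 15000 nM in this assay, with a likely range from 6000 nM to 40000 nM.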

Compound 4, half-maximal inhibitory concentration: 20000 nM
Beside the measured number, compound 4's estimate is 1.3-fold (0.12 log units) below it; measured number inside the range.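

In this assay, placing methyl where fluoro stood on the ketone core gives a 3.3-fold higher number from compound 3 to compound 4 (0.52 log units; beyond the scatter), so the change that made the number higher on the alcohol core does the same here. Set side by side, the two steps agree in direction and, given the ordinary noise of such measurements, in size: the same change on two cores in this assay, a 2.5-fold higher number (0.40 log units; beyond the scatter) from compound 1 to compound 2 and a 3.3-fold higher number (0.52 log units; beyond the scatter) from compound 3 to compound 4, 1.3-fold (0.12 log units) apart, within the scatter of two such steps. This suggests that, within these four compounds, the effect of this swap carries from the alcohol core to the ketone core, but it rests on a single pair for each core and one assay, so it neither establishes a general rule for the series nor explains why the number rises.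

The compounds shown leave open how a chloro or methoxy group would behave on the same aromatic carbon, and whether the step would survive on a core with a longer chain or with a carboxylic acid or an amine at the end of the chain. They also leave open whether the same step would appear in cell types other than the J774 cells used here.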